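The source may report more compounds than this note shows. Statements on the series, on what has been measured and on what is new or still open speak of the compounds shown alone.

In a functional assay on Hs-578T cells (Homo sapiens) for cytotoxicity, read by sulforhodamine B assay, with a stated time of 48 h, tested at 1 uM (on this read-out lower numbers stand for a stronger effect and higher numbers for a weaker effect at the one concentration tested), compound 2, whose structure is `COc1ccc(C(=O)/C=C/c2cc(-c3cc(OC)c(OC)c(OC)c3)n[nH]2)cc1`, gives 96%, the higher of the two numbers in hand, while compound 1, with the structure `COc1ccc(C(=O)/C=C/c2cc(-c3cc(OC)c(OC)c(OC)c3)n[nH]2)cc1OC`, gives 91%. For the measured compounds named here, the only measured step, a number 5 percentage points higher from compound 1 to compound 2 (within the scatter), shows that removing one methoxy from the aryl group on the carbonyl carbon leaves this assay essentially unchanged.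

Compound 3, with the structure `COc1cc(-c2cc(/C=C/C(=O)c3ccc(F)c(F)c3)[nH]n2)cc(OC)c1OC`, has not been measured in this assay. It differs from compound 2 by the change (3,4-difluorophenyl in place of 4-methoxyphenyl on a carbonyl carbon).

Going by the values given here, the one measured step concerns the same aryl group on the carbonyl carbon, and it stayed within the scatter, so it gives little reason to expect a large response to a further change at that position. Among the compounds with values here, no measured pair, however, exchanges a methoxy for fluorine, so the direction of any shift beyond the scatter cannot be read from the data. Compound 3 is therefore expected to sit close to compound 2, with a step of about a number 6 percentage points lower from compound 2 to compound 3 (within the scatter) that does not clearly exceed the scatter, and an estimated value of 90% with a range from 68% to 105%.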

Compound 3, a percentage reported as activity, at one concentration (the size of the read-out at that concentration, not a potency): 86%
The estimate for compound 3 lay 4 percentage points above the measured number; the range from low to high includes it.
By their numbers in this assay, from the lowest: compounds 3, 1 and 2 (each within the scatter of the next).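

For the compounds shown here, exchanging the aryl group on the carbonyl carbon for 3,4-difluorophenyl is the first change here that replaces methoxy with fluorine, and in this assay it gives a number 10 percentage points lower from compound 2 to compound 3 (within the scatter) and a number 5 percentage points lower from compound 1 to compound 3 (within the scatter) when set against the two methoxy-bearing compounds. The earlier step only took away one methoxy, whereas these steps show that this position also accepts an aryl group with no methoxy at all: 4-methoxyphenyl, with its hydrogen-bond acceptor, leaves and 3,4-difluorophenyl, with none, enters, yet the read-out at this one concentration does not separate the compounds. Nothing available here accounts for this insensitivity.

From the compounds shown here alone, all three compounds keep the shared core and vary only in this aryl group, so it remains open whether any group on the carbonyl carbon can move the number beyond the scatter, or whether changes elsewhere on the core matter more. An aryl group carrying an amine or a carboxylic acid, or a saturated alkyl chain in place of the ring, would probe that question in a way these three closely related aryl groups cannot.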